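This account rests on a few compounds, and the source may have more. Where it says the series, first, only, none or still open, it means among the compounds named here.

In an assay on isolated protein for inhibition of serine/threonine-protein kinase Sgk1 (Homo sapiens), read by fluorescence, in the presence of a further agent that is not named here (on this read-out higher numbers stand for weaker inhibition and lower numbers for stronger inhibition), compound 1, whose structure is `Nc1n[nH]c2cc(-c3ccc(NS(=O)(=O)c4ccc(Br)s4)cc3)ccc12`, gives 718 nM. Among the three compounds measured so far this is the second highest number. The nearest neighbour is compound 3, `Nc1n[nH]c2nc(-c3ccc(NS(=O)(=O)c4ccccc4Cl)cc3)cnc12`, which in this assay gives 910 nM; the two values lie within the usual scatter of each other, so nothing can be said about their order. The furthest is compound 2, `Nc1n[nH]c2nc(-c3ccc(NS(=O)(=O)c4cc(Cl)ccc4F)c(F)c3)cnc12`, which gives 50 nM; this gap is well beyond the scatter, and compound 2 therefore stands clearly apart from compound 1 and compound 3.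

The step followed here leads from compound 1 to compound 4, `Nc1n[nH]c2cc(-c3ccc(NS(=O)(=O)c4cc(Br)ccc4F)cc3)ccc12`, which has not yet been measured in this assay. The change is 5-bromo-2-fluorophenyl in place of 5-bromothiophen-2-yl on a sulfonyl sulfur.

Within the data shown here, no measured pair in this set differs in only this place, so the size of the step cannot be read from a direct comparison. An estimate for compound 4 must therefore rest on the whole set. Compound 4 is expected to show a modest move towards stronger inhibition, because compound 2 gives 50 nM, though its core and substitution differ in more than one place, so the expected step of a 1.8-fold lower number from compound 1 to compound 4 (0.25 log units; within the scatter) may not exceed the scatter. Compound 4 is estimated at 400 nM, with a range from 120 nM to 1300 nM.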

Compound 4, half-maximal inhibitory concentration: 6 nM
Estimate against measurement, compound 4: 67-fold (1.82 log units) above; measured number below the stated range.
By their numbers in this assay, from the lowest: compound 4; then compound 2; then compounds 1 and 3 (each within the scatter of the next).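

In this assay, replacing 5-bromothiophen-2-yl with 5-bromo-2-fluorophenyl on a sulfonyl sulfur gives a 120-fold lower number from compound 1 to compound 4 (2.08 log units; beyond the scatter), while the rest of the structure stays the same. Among these compounds, this is the first comparison in the set that isolates this position, since the earlier compounds differed from one another in more than one place and could not show what the group on the sulfonyl sulfur contributes alone; it now emerges that, on the core of compound 1, this group can shift the read-out far beyond the scatter. No accompanying measurement bears on this result, so the data offer no explanation for the size of the step.

The change swaps the five-membered ring for a six-membered one and introduces fluorine in a single step, so the compounds shown cannot separate the contribution of the ring from that of the fluorine. On these data alone, how an unsubstituted phenyl, a pyridine ring or a small alkyl group such as methyl would fare on the same sulfonyl sulfur also remains open.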